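Swapping a Methylsulfanyl Group for Pyrrolidin-1-yl

The compounds below may be only part of what the source reports. "The series", "measured", "known", "first", "only" and "open" are said of these compounds alone.

Compound 1 `CCN(CC)Cc1cc(Br)c(S(C)(=O)=O)cc1C(=O)N=C(N)N`: 9500 nM
Compound 2 `CSc1cc(C)c(C(=O)N=C(N)N)cc1S(C)(=O)=O`: 6 nM

Both compounds were measured in a functional assay for inhibition of sodium/hydrogen exchanger (Oryctolagus cuniculus); on this read-out higher numbers stand for weaker inhibition and lower numbers for stronger inhibition. Compound 2 gives the lowest of the two numbers; compound 1 sits far higher, a gap well beyond the usual scatter. Compound 3 `Cc1cc(N2CCCC2)c(S(C)(=O)=O)cc1C(=O)N=C(N)N` differs from compound 2 in one place: pyrrolidin-1-yl in place of methylsulfanyl on an aromatic carbon. For the measured compounds named here, no measured pair isolates this particular change, so its effect can only be guessed from the shared core. The step of a 3.3-fold higher number from compound 2 to compound 3 (0.52 log units; beyond the scatter) is expected to be modest, toward a somewhat higher number, and could stay within the scatter. Compound 3 is estimated at 20 nM, within a range of 3 nM to 150 nM.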

Compound 3, half-maximal inhibitory concentration: 11 nM
Beside the measured number, compound 3's estimate is 1.8-fold (0.26 log units) above it; the measured number falls inside the stated range.
By their numbers in this assay, from the lowest: compounds 2 and 3 (each within the scatter of the next); then compound 1.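

In this assay, pyrrolidin-1-yl in place of methylsulfanyl gives (a 1.8-fold higher number from compound 2 to compound 3 (0.26 log units; within the scatter)), so compound 2 and compound 3 cannot be told apart. This position, ortho to a methylsulfonyl group, therefore accepts a five-membered non-aromatic ring with more heavy atoms without a measurable change in this read-out. No supporting data bear on why the two groups match. Still open, as far as these compounds go, is whether a piperidine ring or an open-chain dimethylamino group would fit equally well. A hydroxyl group or a plain amine at this position is equally unresolved.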